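The source may hold more compounds than are shown below. What is called first, only, known or untested is meant among the compounds shown, and "the series" means these compounds.

Measured so far:
compound 1 `CN(C)c1ccc(C(=O)N[C@@H](CCCCCC(=O)NO)C(=O)NCc2ccccc2)cc1` — 12000 nM in a functional assay on NFF cells (Homo sapiens) for antiproliferative activity; on this read-out higher numbers stand for weaker inhibition and lower numbers for stronger inhibition
compound 2 `CN(C)c1ccc(C(=O)N[C@@H](CCCCCC(=O)NO)C(=O)NCc2ccccn2)cc1` — 33000 nM
compound 3 `O=C(CCCCC[C@H](NC(=O)c1ccc(Br)cc1)C(=O)NCc1ccccn1)NO` — 2090 nM

Compound 2 stands at the highest number of the three in this assay. Its nearest neighbour is compound 1, a 2.8-fold higher number from compound 1 to compound 2 (0.44 log units; beyond the scatter); furthest is compound 3, a 16-fold lower number from compound 2 to compound 3 (1.20 log units; beyond the scatter).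

Compound 4 `CN(C)c1ccc(C(=O)N[C@@H](CCCCCC(=O)NO)C(=O)Nc2cccc3cccnc23)cc1` differs from compound 2 in one place: quinolin-8-yl in place of (pyridin-2-yl)methyl on an amide-type nitrogen. Within the data shown here, the only measured step touching this position is a 2.8-fold higher number from compound 1 to compound 2 (0.44 log units; beyond the scatter), a change of ring within the methylene-linked group; no measured pair replaces the (pyridin-2-yl)methyl with a ring bound directly to the amide-type nitrogen. The step is therefore expected to stay within the scatter, with a wide range either way.

Compound 4 is estimated at 30000 nM in this assay, range 7000 nM to 130000 nM, which is expected to mean a 1.1-fold lower number from compound 2 to compound 4 (0.04 log units; within the scatter).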

Compound 4, half-maximal inhibitory concentration: 570 nM
Compound 4: middle estimate off by 53-fold (1.72 log units), on the high side; the measured number lies below the stated range.
By their numbers in this assay, from the lowest: compound 4; then compound 3; then compound 1; then compound 2.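

At this amide-type nitrogen, quinolin-8-yl gives much stronger inhibition in (this assay) than either methylene-linked group (a 58-fold lower number from compound 2 to compound 4 (1.76 log units; beyond the scatter); a 21-fold lower number from compound 1 to compound 4 (1.32 log units; beyond the scatter)). Both steps far exceed the change of ring within the methylene-linked group (a 2.8-fold higher number from compound 1 to compound 2 (0.44 log units; beyond the scatter)), so this position can move the number much further than that step showed. Nothing measured here accounts for the gain.

Still open, going by these compounds, is whether the gain follows the direct attachment to the nitrogen or the second ring, which a directly bound pyridin-2-yl or a quinolin-8-ylmethyl group would separate. Also open, on these data alone, is whether bromo in place of dimethylamino (a 16-fold lower number from compound 2 to compound 3 (1.20 log units; beyond the scatter)) carries over to the quinolin-8-yl amide.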